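Replacing Trifluoromethyl by Chloro on the Urea Aryl

The compounds below may be only part of what the source reports. "The series", "measured", "known", "first", "only" and "open" are said of these compounds alone.

Compound 2 `COc1cc2cc(Oc3ccc(NC(=O)Nc4ccc(Cl)c(C(F)(F)F)c4)cc3)c(C)nc2cc1OC` gives the lowest of the two numbers shown in a functional assay on PC-3 cells (Homo sapiens) for inhibition, read by sulforhodamine B assay, with a stated time of 48 h (a lower number here means a stronger inhibitor of growth, a higher number a weaker inhibitor of growth), with 781 nM. Its nearest neighbour is compound 1 `COc1cc2cc(Oc3ccc(NC(=O)Nc4cccc(C(F)(F)F)c4)cc3)c(C)nc2cc1OC`, which in this assay gives 1390 nM; the two are separated by a 1.8-fold lower number from compound 1 to compound 2 (0.25 log units; within the scatter), so neither can be called the stronger inhibitor. Compound 3 `COc1cc2cc(Oc3ccc(NC(=O)Nc4ccc(Cl)c(Cl)c4)cc3)c(C)nc2cc1OC` has not yet been measured. It differs from compound 2 by chloro in place of trifluoromethyl on an aromatic carbon. Among the compounds with values here, no measured step covers this exchange; the only step on record, a 1.8-fold lower number from compound 1 to compound 2 (0.25 log units; within the scatter), concerns the chloro group that stays in place, and it lies within the scatter. The chemist therefore expects no shift beyond the scatter and estimates for compound 3 a value of 900 nM in this assay, with a range from 350 nM to 2300 nM. The step from compound 2 to compound 3 that this estimate implies is expected to be a 1.2-fold higher number from compound 2 to compound 3 (0.06 log units; within the scatter).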

Compound 3, concentration for 50% growth inhibition: 1530 nM
Estimate against measurement, compound 3: 1.7-fold (0.23 log units) below, within the range that was stated.
By their numbers in this assay, from the lowest: compounds 2, 1 and 3 (each within the scatter of the next).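

In this assay, the exchange at this position, ortho to a chloro group, gives a 2.0-fold higher number from compound 2 to compound 3 (0.29 log units; within the scatter) and so does not separate chloro from trifluoromethyl. Read across the whole aryl group, 3,4-dichlorophenyl in place of 3-(trifluoromethyl)phenyl gives a 1.1-fold higher number from compound 1 to compound 3 (0.04 log units; within the scatter) and likewise separates nothing, so the three substitution patterns shown cannot be ranked against one another. No supporting data accompany these values that could explain even these small steps.

From the compounds shown here alone, whether a group of another kind on this aromatic carbon, such as an amine, a methoxy group or a carboxylic acid, would move the number beyond the scatter remains open. Also open, going by these compounds, is whether hydrogen in place of trifluoromethyl, with the chloro group kept, would do so.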